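Shortening the Chain to the Carbonyl: Compound 3

The source may report more compounds than this note shows. Statements on the series, on what has been measured and on what is new or still open speak of the compounds shown alone.

Of the compounds shown here, two sharing one core have been measured in an assay on CHO cells with Alpha-1D adrenergic receptor (Homo sapiens) as the target; a lower number here means a stronger inhibitor, a higher number a weaker inhibitor. Compound 1 `COc1cc2nc(N3CCN(C(=O)CCCCC4CCSS4)CC3)nc(N)c2cc1OC` gives 0.891 nM. Compound 2 `COc1cc2nc(N3CCN(C(=O)CC4CCSS4)CC3)nc(N)c2cc1OC`, which carries the same five-membered ring on a shorter saturated chain, gives 0.389 nM. Going by the values given here, the single step between them, a 2.3-fold lower number from compound 1 to compound 2 (0.36 log units; beyond the scatter), shows that trimming the chain on the saturated chain carbon bound to the carbonyl carbon brought a modest gain, beyond the scatter. Compound 2 therefore stands with the lowest of the two numbers, and compound 1 lies above it by exactly that step.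

Compound 3 `COc1cc2nc(N3CCN(C(=O)C4CCSS4)CC3)nc(N)c2cc1OC` takes the same direction one step further: a group of 5 heavy atoms (3 carbon, 2 sulfur; one five-membered non-aromatic ring with 2 hetero atoms) in place of a group of 6 heavy atoms (4 carbon, 2 sulfur; one five-membered non-aromatic ring with 2 hetero atoms), on a carbonyl carbon, so that the ring now sits directly on the carbonyl carbon whose other neighbour is the amide-type nitrogen in a ring. Among the compounds with values here, only the step from compound 1 to compound 2 bears on this change, and it was modest. In this assay compound 3 is therefore expected to move by a 1.3-fold lower number from compound 2 to compound 3 (0.11 log units; within the scatter), a small downward step that may not exceed the scatter, with an estimated 0.3 nM and a range from 0.12 nM to 0.8 nM.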

Compound 3, inhibition constant: 0.49 nM
For compound 3 the middle estimate is 1.6-fold (0.21 log units) below the measured one; low and high end bracket the measured number.
By their numbers in this assay, from the lowest: compounds 2, 3 and 1 (each within the scatter of the next, the first and the last beyond it).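

In this assay, setting the ring directly on the carbonyl carbon, with no saturated chain carbon left on that side, gives a 1.3-fold higher number from compound 2 to compound 3 (0.10 log units; within the scatter), so compound 2 and compound 3 cannot be told apart at this position. Compared with the longest chain, the change gives a 1.8-fold lower number from compound 1 to compound 3 (0.26 log units; within the scatter), so compound 3 cannot be separated from compound 1 either, even though compound 1 and compound 2 do stand apart by a 2.3-fold lower number from compound 1 to compound 2 (0.36 log units; beyond the scatter); the one clear difference in the series therefore lies between compound 1 and compound 2, and removing the last chain carbon adds no readable gain to it. Nothing measured alongside these numbers accounts for them.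

All three compounds keep the same five-membered ring with two sulfur atoms, which leaves open whether that ring matters at all, or whether a cyclopentyl group or an open-chain thioether on the carbonyl carbon would give a similar number. Also open, from the compounds shown here alone, is how a chain longer than that of compound 1 would read, or a chain of the same length ending in an amine or a carboxylic acid in place of the ring.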